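Aryl swap on an azido-bearing core: expecting compound 3

A few compounds are considered here, and "the series" means these few. Any claim that something is new, unique, unknown or untested is made for them only; others in the source may bear on it.

Compound 1, `COc1cc2nc(-c3ccccc3Cl)nc(N=[N+]=[N-])c2cc1OC`, gives > 10000 nM in a functional assay on HCT-116 cells (Homo sapiens) for cytotoxicity, read by MTT assay, with a stated time of 72 h; on this read-out lower numbers stand for stronger inhibition and higher numbers for weaker inhibition; this is a limit of the assay, not a number.
Compound 2, `COc1cc2nc(-c3cccc(Cl)c3)nc(N=[N+]=[N-])c2cc1OC`, gives 10000 nM.

Within the data shown here, compound 2 carries the only number in this assay; the other value shown is a limit. Among the measured compounds shown here, the one measured step, a number no higher from compound 1 to compound 2 (the limit leaves the size open), cannot be sized, because compound 1 sits at the limit of > 10000 nM in this assay, at which 1 of the 2 values shown sits.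

Compound 3, `COc1ccc(-c2nc(N=[N+]=[N-])c3cc(OC)c(OC)cc3n2)cc1`, is the next compound. Its change from compound 2 is 4-methoxyphenyl in place of 3-chlorophenyl on an aromatic carbon. For the measured compounds named here, no measured step bears on this change: the only step recorded swaps one chlorophenyl for another, and its size is not readable. No direction can therefore be drawn from the data, and the expectation rests on compound 2 alone.

Compound 3 is expected to give about 10000 nM in this assay, within 3000 nM to 30000 nM, so that the estimated step of no change at the digits printed from compound 2 to compound 3 (within the scatter) stays within the usual scatter. There is a real chance that compound 3 returns only a limit, as compound 1 did.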

Compound 3, half-maximal inhibitory concentration: 7000 nM
Estimate against measurement, compound 3: 1.4-fold (0.15 log units) above; low and high end bracket the measured number.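

At this position on the shared core, a 4-methoxyphenyl brings a hydrogen-bond acceptor that the 3-chlorophenyl lacks, yet in this assay the result is a 1.4-fold lower number from compound 2 to compound 3 (0.15 log units; within the scatter), so this swap does not separate the two compounds on this read-out. Set against the other chlorophenyl, the same group gives an at least 1.4-fold lower number from compound 1 to compound 3 (0.15 log units; that floor lies within the scatter). Compound 1 holds only a limit of the assay, so that step has a floor but no true size: the limit of > 10000 nM in this assay, at which 1 of the 3 values shown sits.

The aryl rings shown carry only a single chlorine or a single methoxy group, so it remains open whether a carboxylic acid or an amine on this ring would give a number clearly apart from these. Every compound shown also keeps the azido group and the two methoxy groups of the shared core, and what a simple amine in place of the azido group would give in this assay also remains open.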